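Amide Variation on a Shared Core with a Diol Acid Chain

This account rests on a few compounds, and the source may have more. Where it says the series, first, only, none or still open, it means among the compounds named here.

Compound 1, `Cc1ccc(CNC(=O)c2nn(-c3ccc(F)cc3)c(CC[C@@H](O)C[C@@H](O)CC(=O)O)c2C(C)C)cc1`, gives 800 nM.
Compound 2, `CC(C)c1c(C(=O)N(C)Cc2cccc(F)c2)nn(-c2ccc(F)cc2)c1CC[C@@H](O)C[C@@H](O)CC(=O)O`, gives 1900 nM.
Compound 3, `Cc1ccccc1CNC(=O)c1nn(-c2ccc(F)cc2)c(OC[C@@H](O)C[C@@H](O)CC(=O)O)c1C(C)C`, gives 2850 nM.

In a functional assay on L6 cells (Rattus norvegicus) for inhibition (on this read-out higher numbers stand for weaker inhibition and lower numbers for stronger inhibition), compound 3 stands highest of the three numbers. Its nearest neighbour is compound 2, whose value of 1900 nM lies within the scatter of it, while compound 1, at 800 nM, sits beyond the scatter on the lower side.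

Compound 4, `COc1cccc(CN(C)C(=O)c2nn(-c3ccc(F)cc3)c(OC[C@@H](O)C[C@@H](O)CC(=O)O)c2C(C)C)c1`, is made from compound 3 by a single change at the amide: (3-methoxybenzyl)(methyl)amino in place of (2-methylbenzyl)amino on a carbonyl carbon. Among the compounds with values here, one measured step bears on this. Replacing a (4-methylbenzyl)amino group by a (3-fluorobenzyl)(methyl)amino group gave a 2.4-fold higher number from compound 1 to compound 2 (0.38 log units; beyond the scatter), a modest rise beyond the scatter. The move from compound 3 to compound 4 is of the same kind, pairing a methyl on the amine with a differently substituted benzyl, so a modest rise in this assay is expected, though a single precedent leaves the size uncertain.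

Compound 4 is therefore expected to give 5000 nM, within a range from 2000 nM to 12000 nM. The expected step is a 1.8-fold higher number from compound 3 to compound 4 (0.24 log units; within the scatter).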

Compound 4, half-maximal inhibitory concentration: 9460 nM
Compound 4: the middle estimate sits 1.9-fold (0.28 log units) below what was measured; low and high end bracket the measured number.
By their numbers in this assay, from the lowest: compound 1; then compounds 2 and 3 (each within the scatter of the next); then compound 4.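

In this assay, replacing (2-methylbenzyl)amino with (3-methoxybenzyl)(methyl)amino on the carbonyl carbon gave a 3.3-fold higher number from compound 3 to compound 4 (0.52 log units; beyond the scatter). The rise from the earlier pair therefore recurs on the chain of compound 3, so both listed swaps of a benzylamino group for a methylated one raise the number, on two different chains. Each swap, however, removes the amide hydrogen and changes the ring substituent together, and no measurement shown explains the rise.

The compounds shown leave open how much of the step belongs to the added methyl and how much to the methoxy group, which a (3-methoxybenzyl)amino group on the same chain would separate. Also open, as far as these compounds go, is whether a cyclic amine such as piperidine, or an unsubstituted benzylamino group, would be tolerated at this carbonyl carbon.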